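Swapping a methoxy for chloro on a sulfonamide aryl ring

The compounds below may be only part of what the source reports. "The series", "measured", "known", "first", "only" and "open" are said of these compounds alone.

Measured compounds:
- compound 1, `COc1ccc(Cl)cc1S(=O)(=O)Nc1cncc(-c2cccnc2)c1`: "not determined" (no result reported)
- compound 2, `COc1ccc(OC)c(S(=O)(=O)Nc2cncc(-c3ccncc3)c2)c1`: > 20000 nM
- compound 3, `COc1ccc(Cl)cc1S(=O)(=O)Nc1cncc(C(=O)Nc2ccccc2)c1`: "not determined" (no result reported)

In an assay on isolated protein for inhibition of alkaline phosphatase, tissue-nonspecific isozyme (Homo sapiens) (on this read-out lower numbers stand for stronger inhibition and higher numbers for weaker inhibition), compound 2 gives > 20000 nM, which is a limit of the assay rather than a number. Among the compounds with values here, compound 1 and compound 3 carry no result in this assay, so compound 2 is the only one with any reading, and that reading sits at the limit of > 20000 nM in this assay, at which 1 of the 3 values shown sits. Within the data shown here, no two measured compounds differ in a single place, so no measured step exists to lean on.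

Compound 4, `COc1ccc(Cl)cc1S(=O)(=O)Nc1cncc(-c2ccncc2)c1`, is yet to be measured. The change from compound 2 to compound 4 is chloro in place of methoxy on an aromatic carbon. With nothing measured beyond the limit of compound 2, the size of the step is open; the expectation is that it moves towards stronger inhibition in this assay, beyond the usual scatter, though a further limit cannot be excluded. The step from compound 2 to compound 4 is estimated as an at least 10-fold lower number from compound 2 to compound 4 (1.00 log units; beyond the scatter). Compound 4 is therefore expected to give about 2000 nM, within a range from 150 nM to 20000 nM.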

Compound 4, half-maximal inhibitory concentration: > 20000 nM
Compound 4: only a limit was reported; the forecaster's own chance of this, stated with the estimate: 30%; at least 10-fold (1.00 log units) between middle value and limit.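

Compound 2 and compound 4 both reach only a limit in this assay, not a number, so no step between them can be read: the limit of > 20000 nM in this assay, at which 2 of the 4 values shown sit.

The compounds shown leave open whether chloro in place of methoxy changes inhibition at all.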